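The source may hold more compounds than are shown below. What is called first, only, known or untested is meant among the compounds shown, and "the series" means these compounds.

Within the data shown here, in a functional assay on U-251 cells (Homo sapiens) for cytotoxicity (a lower number here means a stronger inhibitor of growth, a higher number a weaker inhibitor of growth), compound 1 (`COc1ccc(C2=C(c3ccc(SC)cc3)CC3CCCN3C2=O)cc1C`) gives 90 nM while compound 2 (`CSc1ccc(C2=C(c3ccc(O)c(O)c3)C(=O)N3CCCC3C2)cc1`) gives 30000 nM as the higher of the two numbers so far. Compound 3 (`CSc1ccc(C2=C(c3ccc(O)cc3)C(=O)N3CCCC3C2)cc1`) has hydrogen in place of hydroxy on an aromatic carbon, ortho to a hydroxy group and meta to a large group (hydrogen in place of hydroxy on an aromatic carbon), so 3,4-dihydroxyphenyl becomes 4-hydroxyphenyl. Among the measured compounds shown here, the only measured step bearing on this is large, a 330-fold higher number from compound 1 to compound 2 (2.52 log units; beyond the scatter) as 3,4-dihydroxyphenyl replaces 4-methoxy-3-methylphenyl on a double-bonded ring carbon. For the measured compounds named here, that step exchanged the whole aryl group, and no measured pair isolates this single hydroxy. A moderate step to a lower number is therefore expected in this assay and it should cover only part of that distance. The expected move is a 10-fold lower number from compound 2 to compound 3 (1.00 log units; beyond the scatter) with wide uncertainty. For compound 3 the estimate is 3000 nM with an expected range of 400 nM to 20000 nM for now.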

Compound 3, concentration for 50% growth inhibition: > 100000 nM
Compound 3 gave a limit, no number (the forecaster's own chance of this, stated with the estimate: 10%); at least 33-fold (1.52 log units) between middle value and limit.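

For compound 3 the reading in this assay is a limit of the assay and not a number: the limit of > 100000 nM in this assay, at which 1 of the 3 values shown sits. Taking away the single hydroxy from the 3,4-dihydroxyphenyl group, leaving 4-hydroxyphenyl, does not restore growth inhibition but gives an at least 3.3-fold higher number from compound 2 to compound 3 (0.52 log units; beyond the scatter) in the opposite direction to the one estimated, so this hydroxy on its own favours growth inhibition in the pair. The distance to the 4-methoxy-3-methylphenyl group grows to an at least 1100-fold higher number from compound 1 to compound 3 (3.04 log units; beyond the scatter) on the double-bonded ring carbon, which places the strong inhibition of compound 1 with that whole aryl group.

On these data alone, the true size of the hydroxy step stays open, since only its lower bound can be read. Also open, as far as these compounds go, is whether an amine or a fluorine atom at this aromatic carbon would serve as the hydroxy does, and whether a single methoxy would carry the effect of the 4-methoxy-3-methylphenyl group.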